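Removing the oxolan-3-yl group from compound 1

This account rests on a few compounds, and the source may have more. Where it says the series, first, only, none or still open, it means among the compounds named here.

Three compounds of this series carry numbers in an ADME assay on microsomes from liver (Homo sapiens) for metabolic stability, with a stated time of 60 min, tested at 1 uM (a lower number here means that less of the compound is left, a higher number that more of the compound is left), so far. Compound 1 `COc1cc(-c2cnn3cc(OC)c(C4CCOC4)nc23)ccn1` gives 29%, compound 2 `Cn1cc(-c2nc3c(-c4ccnc(OC5CC5)c4)cnn3cc2OCCCC(C)(C)O)cn1` gives 54%, and compound 3 `COc1cn2ncc(-c3ccnc(OC(C)C)c3)c2nc1-c1cnn(C)c1` gives 32%. Compound 1 holds the lowest of the three numbers; compound 3 sits within the scatter of it, while compound 2 lies clearly higher, beyond the scatter. No pair among these three differs in only one place, so no single structural step can be read off the measured set.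

Compound 4 `COc1cnc2c(-c3ccnc(OC)c3)cnn2c1` has not yet been run in this assay. It differs from compound 1 in one place: hydrogen in place of oxolan-3-yl on an aromatic carbon. The group that leaves sits next to the ring nitrogen and ortho to a methoxy group on the shared core of compound 1.

Among the compounds with values here, with no one-place step among the measured compounds to lean on, the size of this step in this assay is uncertain; the expectation is a modest change, most likely none beyond the scatter, with a slight lean upward. The step expected is a number 7 percentage points higher from compound 1 to compound 4 (within the scatter). Compound 4 is estimated at 36%, with a likely range from 16% to 60%.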

Compound 4, percent of the compound remaining: 2%
Compound 4: middle estimate off by 34 percentage points, on the high side; measured number outside the range, below it.
By their numbers in this assay, from the lowest: compound 4; then compounds 1 and 3 (each within the scatter of the next); then compound 2.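

In this assay the series now has its first one-place step: hydrogen in place of oxolan-3-yl gives a number 27 percentage points lower from compound 1 to compound 4 (beyond the scatter) and so lies beyond the scatter. The aromatic carbon next to the ring nitrogen and ortho to a methoxy group is therefore not a neutral place on the shared core, since leaving it bare costs compound remaining in this read-out. No measurement shown gives a reason for this step.

Still open, going by these compounds, is whether the number depends on oxolan-3-yl itself or on any group at this carbon, which a methyl group, an amine or a longer chain at the same place would help to separate. A single step on a single core also leaves open whether the same change would give a step of similar size with other substituents elsewhere on the core.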